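A few compounds are considered here, and "the series" means these few. Any claim that something is new, unique, unknown or untested is made for them only; others in the source may bear on it.

Measured compounds:
Compound 1 `CCOC(=O)[C@@H]1CCCN(S(=N)(=O)c2ccc(S(=O)(=O)N(CC)CC)cc2)C1` gives in a functional assay on MIA PaCa-2 cells (Homo sapiens) for inhibition, read by MTT assay, with a stated time of 3 days (on this read-out lower numbers stand for stronger inhibition and higher numbers for weaker inhibition), only a limit, > 10000 nM.
Compound 2 `CCCN(CCC)S(=O)(=O)c1ccc(S(=O)(=O)N2CCC[C@@H](C(=O)OCC)C2)cc1` gives in this assay only a limit, > 10000 nM.
Compound 3 `CCN(CC)C(=O)c1ccc(S(=O)(=O)N2CCC[C@@H](C(=O)N3CCN(c4nc(C(C)C)no4)CC3)C2)cc1` gives in this assay only a limit, > 10000 nM.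

Compound 3 therefore stands nowhere that can be ranked: its value is a limit of the assay and not a number. Going by the values given here, the same holds across the whole set, since the limit of > 10000 nM in this assay, at which 3 of the 3 values shown sit, covers every value shown, so no step between measured compounds can be drawn and no compound can be placed above or below another.

Compound 4 `CCNS(=O)(=O)c1ccc(S(=O)(=O)N2CCC[C@@H](C(=O)N3CCN(c4nc(C(C)C)no4)CC3)C2)cc1` is the one not yet measured. It differs from compound 3 in a single place, (ethylsulfamoyl in place of diethylcarbamoyl on an aromatic carbon), that is, ethylsulfamoyl in place of diethylcarbamoyl on an aromatic carbon, para to a large group. Among the compounds with values here, nothing among the measured compounds tells how this exchange moves the read-out, because every neighbour sits at the limit of > 10000 nM in this assay, at which 3 of the 3 values shown sit.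

Without a measured step to lean on, the expectation is none beyond the scatter, so that compound 4 most likely remains at the limit as well. The estimated step is a step that the limit leaves unreadable from compound 3 to compound 4. Compound 4 is expected at 15000 nM, with a range from 4000 nM to 60000 nM, and in all likelihood the assay will again report only a limit.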

Compound 4, half-maximal inhibitory concentration: > 10000 nM
Compound 4 was reported as a limit (the forecaster's own chance of this, stated with the estimate: 80%); the middle value lies beyond the limit too.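

No new step can be read between compound 3 and compound 4, since both values are limits and not numbers: the limit of > 10000 nM in this assay, at which 4 of the 4 values shown sit.

From the compounds shown here alone, whether ethylsulfamoyl in place of diethylcarbamoyl on an aromatic carbon moves the read-out at all in this assay stays open, as does any ranking of compound 1, compound 2, compound 3 and compound 4.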